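The source may report more compounds than this note shows. Statements on the series, on what has been measured and on what is new or still open speak of the compounds shown alone.

In a functional assay on the whole organism for inhibition, with Mus musculus as the target (on this read-out lower numbers stand for an effect already at smaller amounts and higher numbers for an effect only at larger amounts of compound), compound 1, with structure `CN1Cc2c(N)cccc2C(c2ccc(Cl)cc2)C1`, gives 1.6 mg/kg. Compound 2, with structure `CC(C)c1ccc(C2CN(C)Cc3c(N)cccc32)cc1`, reaches only the limit of this assay at > 80 mg/kg, so for it no number is known. Among the measured compounds shown here, the change an at least 50-fold higher number from compound 1 to compound 2 (1.69 log units; beyond the scatter) is the only step measured between two numbered compounds, and it is large. Compound 3, with structure `CCOC(=O)Nc1cccc2c1CN(C)CC2c1ccccc1`, gives 3.2 mg/kg in this assay; among the two numbers shown it is the higher one, but its gap to compound 1 lies within the usual scatter of repeated measurements, so the two cannot be told apart.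

Compound 4 has structure `CN1Cc2c(NC(=O)CN3CCCCC3)cccc2C(c2ccccc2)C1` and differs from compound 3 by (piperidin-1-yl)methyl in place of ethoxy on a carbonyl carbon. For the measured compounds named here, the one measured step, from compound 1 to compound 2, concerns a group on an aromatic carbon and not a group on a carbonyl carbon, so it does not bear directly on this change. Going by the values given here, no measured step therefore sets a direction. The expectation is that compound 4 stays close to compound 3, with the step of a 1.3-fold higher number from compound 3 to compound 4 (0.10 log units; within the scatter) lying within the scatter. Compound 4 is therefore estimated at 4 mg/kg in this assay, with a range from 1.5 mg/kg to 12 mg/kg.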

Compound 4, dose for half-maximal effect: about 65 mg/kg
The estimate for compound 4 lay 16-fold (1.21 log units) below the measured number; the whole stated range lies below it.
By their numbers in this assay, from the lowest: compounds 1 and 3 (each within the scatter of the next); then compound 4. At a limit, above all of these: compound 2.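

Exchanging ethoxy for (piperidin-1-yl)methyl on the carbonyl carbon is far from a silent change in this assay, which shows a 20-fold higher number from compound 3 to compound 4 (1.31 log units; beyond the scatter). Among the compounds shown here, this group on the carbonyl carbon therefore has a strong influence on the dose needed, so a large step is no longer confined to the group on an aromatic carbon, where the earlier compounds showed an at least 50-fold higher number from compound 1 to compound 2 (1.69 log units; beyond the scatter). Nothing shown here explains why the new group demands so much more compound.

From the compounds shown here alone, it remains open whether the shift follows from the ring, from the nitrogen or simply from the greater number of heavy atoms in the new group. A small open-chain amine such as (dimethylamino)methyl, or a plain carbon chain such as butyl, on the same carbonyl carbon would help to separate these possibilities.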